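Ethyl to Isopropyl on the Shared Core

A few compounds are considered here, and "the series" means these few. Any claim that something is new, unique, unknown or untested is made for them only; others in the source may bear on it.

Of the compounds shown here, two have been measured so far. In an in vitro ADME assay on microsomes from liver (Mus musculus) for pharmacokinetics, read by LC-MS, with a stated time of 10 min, tested at 1 uM (on this read-out higher numbers stand for fast clearance and lower numbers for slow clearance), compound 1 (`CN1C[C@H](C(=O)Nc2ccc(F)c(Cl)c2)[C@@H](c2ccc(/C=C/C(=O)Nc3ccccc3N)cc2)C1`) gives 34 mL/min/kg and compound 2 (`CCN1C[C@H](C(=O)Nc2ccc(Cl)cc2)[C@@H](c2ccc(/C=C/C(=O)Nc3ccccc3N)cc2)C1`) gives 35 mL/min/kg, so compound 2 stands level with compound 1, within the scatter. Compound 3 (`CC(C)N1C[C@H](C(=O)Nc2ccc(Cl)cc2)[C@@H](c2ccc(/C=C/C(=O)Nc3ccccc3N)cc2)C1`) differs from compound 2 in one place: methyl in place of hydrogen on a saturated chain carbon bound to an amine nitrogen in a ring and a saturated chain carbon. This is methyl in place of hydrogen on a saturated chain carbon bound to an amine nitrogen in a ring and a saturated chain carbon, which turns ethyl into isopropyl. For the measured compounds named here, no measured pair shows this change alone, so the expectation rests on compound 2 at 35 mL/min/kg. In this assay, no shift beyond the scatter is expected. The estimated 1.1-fold higher number from compound 2 to compound 3 (0.04 log units; within the scatter) is correspondingly small. Compound 3 is expected to give 38 mL/min/kg, with an estimated range of 20 mL/min/kg to 68 mL/min/kg.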

Compound 3, clearance: 38 mL/min/kg
For compound 3 middle estimate and measured number coincide at the digits printed, within the range that was stated.
By their numbers in this assay, from the lowest: compounds 1, 2 and 3 (each within the scatter of the next).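

For the compounds shown here, the earlier compounds offered no comparison in a single place, and this pair is the first: in this assay the change from ethyl to isopropyl gives a 1.1-fold higher number from compound 2 to compound 3 (0.04 log units; within the scatter). For this one pair, then, methyl in place of hydrogen on a saturated chain carbon bound to an amine nitrogen in a ring and a saturated chain carbon leaves the clearance reading within the usual scatter. Nothing measured here speaks to the reason for this result.

On these data alone, whether a longer chain such as butyl, or a cyclopropyl group, would also stay within the scatter at this place remains open. Equally open, as far as these compounds go, is what a hydroxyl, an amine or a carboxylic acid carried on that chain would do to the clearance reading.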